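A few compounds are considered here, and "the series" means these few. Any claim that something is new, unique, unknown or untested is made for them only; others in the source may bear on it.

Measured in an ADME assay on microsomes from liver (Mus musculus, strain NMRI) for metabolic stability, tested at 2.5 uM; a higher number here means faster removal of the compound, a lower number slower removal:

Compound 1, `Fc1cc(Cl)ccc1-c1ccc(Cn2nnc3ccccc32)cn1`: 3.4 mL/min/g
Compound 2, `Clc1ccc(-c2ccc(Cn3nnc4ccccc43)cn2)cc1`: 3.8 mL/min/g
Compound 3, `Clc1ccc(Cn2nnc3c(Br)cccc32)cc1`: 2 mL/min/g

Compound 1 differs from compound 2 by fluoro in place of hydrogen on an aromatic carbon, and that change gave a 1.1-fold lower number from compound 2 to compound 1 (0.05 log units; within the scatter). Compound 3 carries a different core; how its core differs from that of compound 2 is not broken down here, and its own value in this assay stands within the scatter of the other two.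

Compound 4, `Fc1cc(Cn2nnc3c(Br)cccc32)ccc1Cl`, has not yet been measured. It differs from compound 3 by fluoro in place of hydrogen on an aromatic carbon. This is the same kind of change as from compound 2 to compound 1, but not the same: in compound 1 the entering fluoro stands ortho to a large group and meta to a chloro group, whereas in compound 4 it stands ortho to a chloro group and meta to a large group.

For compound 4 the expected step in this assay is a 1.1-fold lower number from compound 3 to compound 4 (0.02 log units; within the scatter), because the comparable change gave a 1.1-fold lower number from compound 2 to compound 1 (0.05 log units; within the scatter). Compound 4 is therefore estimated at 1.9 mL/min/g, with a likely range from 1 mL/min/g to 3.6 mL/min/g.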

Compound 4, intrinsic clearance in a liver preparation (reported as CLH), per the amount of preparation that the assay uses: 2.2 mL/min/g
For compound 4 the middle estimate is 1.2-fold (0.06 log units) below the measured one, within the range that was stated.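

In this assay fluoro in place of hydrogen on an aromatic carbon gave a 1.1-fold higher number from compound 3 to compound 4 (0.04 log units; within the scatter) and, set beside the earlier case, the two steps do not differ: the same change on two cores in this assay, a 1.1-fold lower number (0.05 log units; within the scatter) from compound 2 to compound 1 and a 1.1-fold higher number (0.04 log units; within the scatter) from compound 3 to compound 4, 1.2-fold (0.09 log units) apart, within the scatter of two such steps. On these two cores, then, the change carried over without a step beyond the scatter on either core, and the core of compound 3 gave the same reading as the core of compound 2. For the compounds shown here, this rests on only two pairs and does not show that the result would hold on further cores; nor can these pairs separate the effect of the core from that of the fluoro's place, which in compound 4 is ortho to a chloro group and meta to a large group.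

The compounds shown leave open whether a methoxy group, a trifluoromethyl group or an amine in place of that hydrogen would also leave the number within the scatter. They also leave open how fluoro would read at other places on the same ring.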